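Notes on the group at the double-bonded nitrogen

The compounds below may be only part of what the source reports. "The series", "measured", "known", "first", "only" and "open" are said of these compounds alone.

- compound 1 `C=CC/N=C1\S/C(=C\c2ccc(OC)cc2)C(=O)N1C` – > 100000 nM (limit)
- compound 2 `COc1ccc(/C=C2\S/C(=N\c3ccc(F)cc3)N(C)C2=O)cc1` – 66500 nM

Compound 1 stands at > 100000 nM in a functional assay on MCF7 cells (Homo sapiens) for antiproliferative activity, read by MTT assay, with a stated time of 72 h (a lower number here means a stronger inhibitor, a higher number a weaker inhibitor), as a limit of the assay, not a number. Among the measured compounds shown here, compound 2 at 66500 nM holds the only true number, so no other number exists to rank it against. Compound 3 `COc1ccc(/C=C2\S/C(=N\c3c(C)cccc3C)N(C)C2=O)cc1` keeps the shared core and changes one group 2,6-dimethylphenyl in place of 4-fluorophenyl on a double-bonded nitrogen with 2,6-dimethylphenyl in place of 4-fluorophenyl on a double-bonded nitrogen. For the measured compounds named here, the one measured step at this place is an at least 1.5-fold lower number from compound 1 to compound 2 (0.17 log units; that floor lies within the scatter) and it starts from a limit, so it gives a floor and no true size. That step also compares allyl with an aromatic ring, whereas here one aromatic ring replaces another. Going by these compounds, with only compound 2 at 66500 nM to build on, no step beyond the scatter is expected in this assay and the direction stays open. The estimated step is a 1.1-fold higher number from compound 2 to compound 3 (0.02 log units; within the scatter) and stays within the scatter. Compound 3 is expected at 70000 nM within an estimated range of 30000 nM to 100000 nM and could also return only a limit.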

Compound 3, half-maximal inhibitory concentration: > 100000 nM
Compound 3: only a limit was reported; the forecaster's own chance of this, stated with the estimate: 30%; middle value at least 1.4-fold (0.15 log units) away from the limit.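

Among the compounds shown here, replacing 4-fluorophenyl with 2,6-dimethylphenyl on a double-bonded nitrogen gives an at least 1.5-fold higher number from compound 2 to compound 3 (0.17 log units; that floor lies within the scatter) in this assay; this is the first change at this place in which one aromatic ring replaces another, and no gain over compound 2 appears. Going by these compounds, the value of compound 3, > 100000 nM, is a limit of the assay and not a number, so the step is a floor, its true size is unknown, and that floor does not pass the usual scatter. Of the allyl, 4-fluorophenyl and 2,6-dimethylphenyl groups at this place, only 4-fluorophenyl yields a true number, leaving the series with little readable range: the limit of > 100000 nM in this assay, at which 2 of the 3 values shown sit.

The step from compound 1 to compound 3 cannot be read, as both values are limits. On these data alone, whether an amine, a carboxylic acid or a longer chain on the double-bonded nitrogen would give a true number clearly lower than that of compound 2 stays open.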